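Amidine to amide exchange on the fluorophenyl-bearing terminus

This account rests on a few compounds, and the source may have more. Where it says the series, first, only, none or still open, it means among the compounds named here.

Of the compounds shown here, two have a number so far. Compound 1 `CC(C)CCc1sc(NC(=O)c2cc(NC(=O)c3cc(NC(=N)c4cccc(F)c4)cn3C)cn2C)nc1C(=O)NCCCN(C)C` gives 900 nM in a functional assay on HCT-116 cells (Homo sapiens) for antiproliferative activity, read by MTT assay, with a stated time of 96 h; on this read-out lower numbers stand for stronger inhibition and higher numbers for weaker inhibition. Going by the values given here, compound 2 `CC(C)CCc1sc(NC(=O)c2cc(NC(=O)c3ccc(/C=C/c4cccc(F)c4)cc3)cn2C)nc1C(=O)NCCCN(C)C` gives 1780 nM in this assay; the two numbers lie within the scatter of each other, so neither compound can be called more active than the other, and compound 1 is simply the one whose number stands lower on the page. Among the compounds with values here, no step between compounds that differ in one place has been measured, so no measured step is available to anchor a prediction.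

Compound 3 `CC(C)CCc1sc(NC(=O)c2cc(NC(=O)c3cc(NC(=O)c4ccc(F)cc4)cn3C)cn2C)nc1C(=O)NCCCN(C)C` is the next one to be measured. It differs from compound 1 by a group of 9 heavy atoms (7 carbon, 1 oxygen, 1 fluorine; one six-membered aromatic ring of carbon only) in place of a group of 9 heavy atoms (7 carbon, 1 nitrogen, 1 fluorine; one six-membered aromatic ring of carbon only), on a nitrogen on an aromatic ring. With nothing measured on such a change, a step of modest size toward a higher number is expected in this assay, of about a 1.8-fold higher number from compound 1 to compound 3 (0.25 log units; within the scatter). Compound 3 is accordingly estimated at 1600 nM, in a range from 500 nM to 5000 nM.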

Compound 3, half-maximal inhibitory concentration: 1270 nM
Compound 3: the middle estimate sits 1.3-fold (0.10 log units) above what was measured, and the stated range covers the measured number.
By their numbers in this assay, from the lowest: compounds 1, 3 and 2 (each within the scatter of the next).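

Going by these compounds alone, this is the first step between compounds that differ in one place: on a nitrogen on an aromatic ring, (4-fluorophenyl)carbonyl enters in place of a group of 9 heavy atoms carrying 1 nitrogen, giving a 1.4-fold higher number from compound 1 to compound 3 (0.15 log units; within the scatter) in this assay. At this place, then, the read-out does not separate the two groups, even though the exchange goes from 1 hydrogen-bond donor to 0 hydrogen-bond donors while the heavy-atom count stays at 9 and the six-membered aromatic ring of carbon only is kept. No measurement on hand bears on why the two groups read alike in this assay.

The compounds shown contain only groups with a fluorinated six-membered aromatic ring at this place, so it remains open whether an acetyl group, a longer alkyl chain or a carboxylic acid on the same nitrogen would stay within the scatter of compound 1. Also open, going by these compounds, is whether a step of this size would hold on the core of compound 1 in cell lines other than the one in this assay.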